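A few compounds are considered here, and "the series" means these few. Any claim that something is new, unique, unknown or untested is made for them only; others in the source may bear on it.

Going by the values given here, in a physicochemical assay for solubility, in phosphate buffer, with a stated time of 18 h, at pH 7.4 (a lower number here means a less soluble compound, a higher number a more soluble compound), only two compounds have numbers so far: compound 1 `Nc1nc(-c2ccccc2)nn1-c1ncnc2ccccc12` gives 1000 nM and compound 2 `COc1cc2nc(C)nc(-n3nc(-c4ccccn4)nc3N)c2cc1OC` gives 16000 nM as the higher of the two, a gap beyond the usual scatter. Compound 3 `COc1cc2nc(N)nc(-n3nc(-c4ccccn4)nc3N)c2cc1OC` has not yet been measured. It differs from compound 2 in one place, with amino in place of methyl on an aromatic carbon between two ring nitrogen atoms. Among the compounds with values here, no pair of measured compounds shows this change, so the data offer no direct guide to its size. A single swap on an otherwise unchanged structure is expected to give a modest step, perhaps slightly downward and possibly none beyond the scatter. Starting from compound 2 at 16000 nM the expected change is a 1.6-fold lower number from compound 2 to compound 3 (0.20 log units; within the scatter) as an estimate only. Compound 3 is estimated at 10000 nM with an expected range of 2500 nM to 40000 nM (not yet measured).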

Compound 3, solubility: 27000 nM
For compound 3 the middle estimate is 2.7-fold (0.43 log units) below the measured one; measured number inside the range.
By their numbers in this assay, from the lowest: compound 1; then compounds 2 and 3 (each within the scatter of the next).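

In this assay the swap of amino for methyl on an aromatic carbon between two ring nitrogen atoms now has its first direct comparison, and it gives a 1.7-fold higher number from compound 2 to compound 3 (0.23 log units; within the scatter). This single pair shows that, on this core, the read-out does not separate the two groups, even though amino brings a hydrogen-bond donor and acceptor that methyl lacks. No measurement shown bears on the reason for this result.

The compounds shown leave open what a different group at this position, such as dimethylamino or a carboxylic acid, would do to the number in this assay. They also leave open whether amino in place of methyl would give a similarly small step on a different core.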